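The source may report more compounds than this note shows. Statements on the series, on what has been measured and on what is new or still open speak of the compounds shown alone.

Series in a functional assay on FaDu cells (Homo sapiens) for cytotoxicity, read by MTT assay, with a stated time of 72 h; on this read-out lower numbers stand for higher toxicity in this test and higher numbers for lower toxicity in this test:
- Compound 1 `CCn1cc(C(=O)C(=O)Nc2ccncc2)c2ccccc21`: > 10000 nM
- Compound 2 `COc1ccc(NC(=O)C(=O)c2cn(C(C)C)c3ccccc23)nn1`: 2270 nM
- Compound 3 `COCCn1cc(C(=O)C(=O)Nc2ccc(OC(C)(C)C)nc2)c2ccccc21`: 858 nM

The entry for compound 1 is a limit of the assay, not a number. Compound 2, at 2270 nM, holds the higher of the two true numbers. Compound 3 gives 858 nM, a gap beyond the scatter.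

Compound 4 `COc1nc(NC(=O)C(=O)c2cn(C(C)C)c3ccccc23)ns1` differs from compound 2 on the amide-type nitrogen: a group of 7 heavy atoms (3 carbon, 2 nitrogen, 1 oxygen, 1 sulfur; one five-membered aromatic ring with 3 hetero atoms) in place of a group of 8 heavy atoms (5 carbon, 2 nitrogen, 1 oxygen; one six-membered aromatic ring with 2 hetero atoms), on an amide-type nitrogen. For the measured compounds named here, no measured step covers this exchange, so no change beyond the scatter is expected in this assay, and no direction is favoured. The estimated step is a 1.3-fold lower number from compound 2 to compound 4 (0.10 log units; within the scatter). For compound 4 the expected value is 1800 nM, with an estimated range of 400 nM to 8000 nM.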

Compound 4, concentration lethal to 50% of the cells: > 10000 nM
Compound 4 was reported as a limit (the forecaster's own chance of this, stated with the estimate: 12%); middle value at least 5.5-fold (0.74 log units) away from the limit.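

For the compounds shown here, on the amide-type nitrogen, the ring exchange gives the first readable step in this assay, an at least 4.4-fold higher number from compound 2 to compound 4 (0.64 log units; beyond the scatter), so the ring on this nitrogen does bear on the read-out even though the two groups are close in size. Compound 4 gives > 10000 nM, which is a limit of the assay and not a number. The full size of the step therefore stays unread, and this limit now recurs within the series: the limit of > 10000 nM in this assay, at which 2 of the 4 values shown sit.

The compounds shown leave open whether the step follows the ring size or the sulfur. Also open, going by these compounds, is how an amine in place of the methoxy on the five-membered ring would read in this assay.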